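Chloro in Place of Methoxy on a Shared Core

The source may hold more compounds than are shown below. What is called first, only, known or untested is meant among the compounds shown, and "the series" means these compounds.

Of the compounds shown here, three built on one shared core have been measured in an ADME assay on Vero cells (Chlorocebus sabaeus) for cytotoxicity, read by neutral red uptake, tested at 98 ug/mL; a higher number here means a weaker effect of the compound at the concentration tested, a lower number a stronger effect. Compound 1 `O=C1CSC(c2ccc([N+](=O)[O-])cc2)N1CCN1CCCCC1` gives 87% in this assay. Compound 2 `COc1ccccc1C1SCC(=O)N1CCN1CCCCC1` gives 100% in this assay, the highest of the three numbers. Compound 3 `COc1cccc(C2SCC(=O)N2CCN2CCCCC2)c1` gives 84% in this assay. The gap between compound 2 and compound 1 lies beyond the usual scatter, and the larger gap between compound 2 and compound 3 lies beyond it as well. Compound 2 stands alone at the top of this small set.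

Compound 4 `O=C1CSC(c2ccccc2Cl)N1CCN1CCCCC1` has not yet been measured in this assay. It differs from compound 2 in one place: chloro in place of methoxy on an aromatic carbon. For the measured compounds named here, no pair of the measured compounds differs in only one place, so no measured step guides this change directly. Since all three measured numbers sit high, compound 4 is expected to stay in that region, with a step from compound 2 of a number 10 percentage points lower from compound 2 to compound 4 (within the scatter) that is small and downward, if it rises above the scatter at all. The estimate for compound 4 in this assay is 90%, within a range from 72% to 100%.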

Compound 4, a percentage reported as activity, at one concentration (the size of the read-out at that concentration, not a potency): 94%
Estimate against measurement, compound 4: 4 percentage points below; the measured number falls inside the stated range.
By their numbers in this assay, from the lowest: compounds 3, 1, 4 and 2 (each within the scatter of the next, the first and the last beyond it).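

In this assay, for the compounds shown here, this is the first step between two compounds that differ in only one place: the change gives a number 6 percentage points lower from compound 2 to compound 4 (within the scatter) and so leaves the read-out inside the usual scatter. On this aromatic carbon, ortho to a large group, methoxy can therefore be exchanged for chloro without a change that can be told apart from repeat-to-repeat variation, something that compounds 1, 2 and 3 could not show among themselves. Nothing available here gives a reason for this outcome.

From the compounds shown here alone, whether an amine, a carboxylic acid or a longer chain such as propoxy on the same carbon would also stay within the scatter remains open. So does whether chloro in place of methoxy would behave in the same way on a different carbon of the ring, as one step at one position says nothing about the others.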